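The compounds below may be only part of what the source reports. "The series", "measured", "known", "first", "only" and "open" are said of these compounds alone.

Measured in a functional assay on HCT-116 cells (Homo sapiens) for antiproliferative activity, read by CCK-8 assay, with a stated time of 72 h; on this read-out higher numbers stand for weaker inhibition and lower numbers for stronger inhibition:
- compound 1 `Cc1ccc(Nc2nc(Cl)nc3c2ncn3Cc2ccc(C(=O)Nc3ccccc3N)cc2)cc1`: 580 nM
- compound 2 `Nc1ccccc1NC(=O)c1ccc(CNc2nc(Cl)nc3c2ncn3C2CCCC2)cc1`: 850 nM
- compound 3 `CCCCn1cnc2c(Nc3ccccc3)nc(NCOCc3ccc(C(=O)Nc4ccccc4N)cc3)nc21`: 1190 nM

In this assay, compound 1 gives 580 nM, which lies within the scatter of compound 2 at 850 nM. Compound 3, at 1190 nM, gives a higher number than compound 1, and that gap lies beyond the scatter.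

Compound 4 `CN1CCN(c2nc(Cl)nc3c2ncn3Cc2ccc(C(=O)Nc3ccccc3N)cc2)CC1` keeps the core of compound 1 and changes one place: 4-methylpiperazin-1-yl stands in place of (4-methylphenyl)amino on an aromatic carbon (4-methylpiperazin-1-yl in place of (4-methylphenyl)amino on an aromatic carbon). Among the measured compounds shown here, no measured pair shows this exchange, so the direction is poorly supported. The three measured compounds differ in several places yet stay close together in this assay, so a modest step towards a higher number is expected rather than a large one. The expected step is a 1.6-fold higher number from compound 1 to compound 4 (0.19 log units; within the scatter). For compound 4 the estimated value is 900 nM, with an expected range from 300 nM to 2800 nM.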

Compound 4, half-maximal inhibitory concentration: 310 nM
Estimate against measurement, compound 4: 2.9-fold (0.46 log units) above, and the stated range covers the measured number.
By their numbers in this assay, from the lowest: compounds 4, 1, 2 and 3 (each within the scatter of the next, the first and the last beyond it).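

Among the compounds shown here, this is the first step that changes a single place, and it concerns the aromatic carbon next to the ring nitrogen and opposite the ring nitrogen, where the earlier compounds offered no direct comparison. In this assay, 4-methylpiperazin-1-yl in place of (4-methylphenyl)amino gives a 1.9-fold lower number from compound 1 to compound 4 (0.27 log units; within the scatter), so a non-aromatic ring with 2 hetero atoms can replace the aromatic ring of carbon only at this position with no change beyond the scatter. No measurement at hand gives a reason for this outcome.

The compounds shown leave open whether a morpholine, a piperidine or an open-chain dimethylamino group at this carbon would read the same way. They also leave open whether the parent piperazine, without its methyl group, would stay within this range.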